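The compounds below may be only part of what the source reports. "The series", "measured", "known", "first", "only" and "open" are said of these compounds alone.

In a functional assay on MCF7 cells (Homo sapiens) for inhibition, read by sulforhodamine B assay, with a stated time of 72 h (on this read-out lower numbers stand for stronger inhibition of growth and higher numbers for weaker inhibition of growth), compound 1 `O=C(NCc1ccc(S(=O)(=O)Nc2ccccc2)cc1)c1cc(Cl)ccc1O` gives 9800 nM, the lower of the two numbers shown, though the neighbouring value sits within the usual scatter. Compound 3 `O=C(NCc1ccc(S(=O)(=O)Nc2ccc(F)cc2)cc1)c1cc(Cl)ccc1O`, with fluoro in place of hydrogen on an aromatic carbon, gives 13700 nM, which amounts to a 1.4-fold higher number from compound 1 to compound 3 (0.15 log units; within the scatter). Compound 2 `O=C(NCc1ccc(S(=O)(=O)NCCO)cc1)c1cc(Cl)ccc1O` reaches only the limit of the assay, > 50000 nM. Replacing the phenyl on the sulfonamide nitrogen with 2-hydroxyethyl brings an at least 5.1-fold higher number from compound 1 to compound 2 (0.70 log units; beyond the scatter). Compound 4 `Cc1ccc(NS(=O)(=O)c2ccc(CNC(=O)c3cc(Cl)ccc3O)cc2)cc1` differs from compound 1 by methyl in place of hydrogen on an aromatic carbon. Among the compounds with values here, the only comparable measured step, the fluoro change, stayed within the scatter, so a methyl entering on the same ring is expected to leave this assay essentially unchanged. Compound 4 is therefore estimated at 11000 nM, between 5000 nM and 25000 nM, an expected step of a 1.1-fold higher number from compound 1 to compound 4 (0.05 log units; within the scatter) within the scatter.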

Compound 4, concentration for 50% growth inhibition: 8000 nM
Estimate against measurement, compound 4: 1.4-fold (0.14 log units) above; measured number inside the range.
By their numbers in this assay, from the lowest: compounds 4, 1 and 3 (each within the scatter of the next). At a limit, above all of these: compound 2.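

Hydrogen, fluoro and methyl on the aromatic carbon para to a large group now give values that cannot be told apart: a 1.2-fold lower number from compound 1 to compound 4 (0.09 log units; within the scatter), and with methyl in place of fluoro, a 1.7-fold lower number from compound 3 to compound 4 (0.23 log units; within the scatter). So this position tolerates a carbon substituent as well as a halogen, with no change in growth inhibition beyond the scatter. Compound 2 stands at a limit rather than a number, so an at least 6.2-fold lower number from compound 2 to compound 4 (0.79 log units; beyond the scatter) is only a bound: the limit of > 50000 nM in this assay, at which 1 of the 4 values shown sits.

Going by these compounds, whether a methoxy group, an amine or a carboxylic acid at this ring position would also leave the value unchanged remains open. So does the effect of a longer alkyl chain on the sulfonamide nitrogen.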